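A few compounds are considered here, and "the series" means these few. Any claim that something is new, unique, unknown or untested is made for them only; others in the source may bear on it.

The series shares the core seen in compound 1 `O=S(=O)(Nc1ccc2oc(-c3ccccc3)nc2c1)c1ccc(Cl)c(Cl)c1`, a sulfonamide whose sulfonyl sulfur carries an aryl group. In an ADME assay on HEK293 cells (Homo sapiens) for cytotoxicity, read by resazurin assay, with a stated time of 48 h (on this read-out higher numbers stand for lower toxicity in this test and lower numbers for higher toxicity in this test), compound 1 gives 71000 nM. Compound 2 `COc1ccc(Cl)cc1S(=O)(=O)Nc1ccc(-c2nc3ccccc3o2)cc1` carries a 5-chloro-2-methoxyphenyl on the sulfonyl sulfur; in this assay compound 2 gives 75000 nM, which sits within the usual scatter of compound 1, so the two cannot be ordered. Compound 3 `O=S(=O)(Nc1ccc2oc(-c3ccccc3)nc2c1)c1ccc(O)cc1` gives > 100000 nM in this assay, a limit of the assay rather than a number. Compound 3 thus stands at the limit of > 100000 nM in this assay, at which 1 of the 3 values shown sits. Among the compounds with values here, the one step between measured compounds that differ in a single place is an at least 1.4-fold higher number from compound 1 to compound 3 (0.14 log units; that floor lies within the scatter); its floor lies within the scatter, so it does not show a change beyond the scatter.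

Compound 4 `O=S(=O)(Nc1ccc(-c2nc3ccccc3o2)cc1)c1ccccc1F` is not yet measured. Between compound 2 and compound 4 the change is 2-fluorophenyl in place of 5-chloro-2-methoxyphenyl on a sulfonyl sulfur. Within the data shown here, this swap, like the step from compound 1 to compound 3, alters only the aryl on the sulfonyl sulfur, and that step did not rise beyond the scatter at its floor; nothing among the measured compounds points to a change beyond the scatter in this assay. Compound 4 is therefore expected to give about 80000 nM in this assay, between 40000 nM and 160000 nM. That estimate means a step of a 1.1-fold higher number from compound 2 to compound 4 (0.03 log units; within the scatter), which is expected to stay within the scatter.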

Compound 4, half-maximal cytotoxic concentration: > 100000 nM
Compound 4 was reported as a limit; the forecaster's own chance of this, stated with the estimate: 35%; middle value at least 1.2-fold (0.09 log units) from the limit.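

In this assay, the swap of 5-chloro-2-methoxyphenyl for 2-fluorophenyl on the sulfonyl sulfur gives an at least 1.3-fold higher number from compound 2 to compound 4 (0.12 log units; that floor lies within the scatter). The earlier step at this position was read on the core of compound 1 and this one on the core of compound 2, so a change of aryl group at the sulfonyl sulfur now has a floor within the scatter on both. Compound 4 gives > 100000 nM, which is a limit of the assay and not a number. With compound 3, the limit is now reached by compounds with two different aryl groups on the sulfonyl sulfur and on two different cores: the limit of > 100000 nM in this assay, at which 2 of the 4 values shown sit.

Both steps are floors, so the compounds shown leave open how large either change really is, and whether any aryl swap at this position moves the number beyond the scatter. On these data alone, it also remains open what an amine, a carboxylic acid or a nitrile on this aryl group would do in this assay, and whether a group other than an aryl on the sulfonyl sulfur would give a different result.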